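Replacing a Hydroxyalkyl Tail with a Sulfonylpiperazine

The source may report more compounds than this note shows. Statements on the series, on what has been measured and on what is new or still open speak of the compounds shown alone.

Measured compounds:
- compound 1, `COc1cc(N)c(Cl)cc1C(=O)NC1CCNCC1`: 1580 nM
- compound 2, `COc1cc(N)c(Cl)cc1C(=O)NC1CCN(CCCCCCCCO)CC1`: 79.4 nM

In an assay on HEK293 cells for displacement of a labelled ligand from 5-hydroxytryptamine receptor 4 (Homo sapiens), read by scintillation counting (a lower number here means a stronger inhibitor, a higher number a weaker inhibitor), compound 1 gives 1580 nM, while compound 2 gives 79.4 nM. Within the data shown here, compound 2 therefore stands at the lowest of the two numbers known, and the one measured step, a 20-fold lower number from compound 1 to compound 2 (1.30 log units; beyond the scatter), comes from adding an 8-hydroxyoctyl group to the ring amine nitrogen of compound 1.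

The next compound, compound 3, `COc1cc(N)c(Cl)cc1C(=O)NC1CCN(CCN2CCN(S(C)(=O)=O)CC2)CC1`, keeps that substituted ring nitrogen but changes the tail: 4-(methylsulfonyl)piperazin-1-yl in place of 6-hydroxyhexyl on a saturated chain carbon, two bonds along the chain from an amine nitrogen in a ring. Among the measured compounds shown here, no measured step tells how a change within the chain beyond the ring nitrogen affects this assay; the only guidance is that compound 2, which carries a substituent there, sits well below compound 1 in this assay. Compound 3 still carries a substituent on that nitrogen, so a step of modest size in either direction is expected, a 1.3-fold lower number from compound 2 to compound 3 (0.12 log units; within the scatter). Compound 3 is expected to give about 60 nM in this assay, within a range from 15 nM to 250 nM.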

Compound 3, inhibition constant: 126 nM
The estimate for compound 3 lay 2.1-fold (0.32 log units) below the measured number; low and high end bracket the measured number.
By their numbers in this assay, from the lowest: compounds 2 and 3 (each within the scatter of the next); then compound 1.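

In this assay, the tail at this position can be exchanged for a very different one with no clear loss: the swap gives a 1.6-fold higher number from compound 2 to compound 3 (0.20 log units; within the scatter), so the two compounds cannot be told apart. The 6-hydroxyhexyl group has a hydrogen-bond donor and no ring, whereas 4-(methylsulfonyl)piperazin-1-yl has no hydrogen-bond donor and a six-membered non-aromatic ring, so in this pair neither a terminal hydroxyl nor an open chain is needed to keep the number at this level. Nothing available explains why these two tails read alike.

From the compounds shown here alone, what remains open is which part of the new tail matters, since the piperazine ring and the methylsulfonyl group arrive together in a single change; a piperazine carrying an acetyl group in place of methylsulfonyl, or a free amine at that nitrogen, would begin to separate the two. The compounds shown also leave open how the length of the link counts, which a longer chain between the ring amine nitrogen and the piperazine would address.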